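This account rests on a few compounds, and the source may have more. Where it says the series, first, only, none or still open, it means among the compounds named here.

Three compounds have been run through a functional assay on SK-OV-3 cells (Homo sapiens) for antiproliferative activity, read by MTT assay, with a stated time of 72 h; on this read-out higher numbers stand for weaker inhibition and lower numbers for stronger inhibition. Compound 1 `CCN1C(=O)/C(=C/N2N=C(c3ccccc3)CC2c2ccccc2O)SC1=S` reaches only a limit of the assay, (the limit of > 10000 nM in this assay, at which 1 of the 3 values shown sits), so its result > 10000 nM is not a number. Compound 2 `O=C1NC(=S)S/C1=C\N1N=C(c2ccc(Cl)cc2)CC1c1ccc(Cl)cc1` gives 9140 nM and compound 3 `O=C1/C(=C/N2N=C(c3ccc4ccccc4c3)CC2c2ccccc2O)SC(=S)N1c1cccnc1` gives 5590 nM; compound 2 thus has the higher of the two numbers, though its gap to compound 3 lies within the scatter. Compound 4 `O=C1NC(=S)S/C1=C\N1N=C(c2ccc3ccccc3c2)CC1c1ccc(Cl)cc1` is not yet measured. It differs from compound 2 in one place: naphthalen-2-yl in place of 4-chlorophenyl on a carbon with a double bond to nitrogen. Going by the values given here, no measured pair shows this exact change. Compound 3 also carries naphthalen-2-yl and gives 5590 nM. On that basis, for compound 4 a step no larger than the scatter is expected a 1.5-fold lower number from compound 2 to compound 4 (0.18 log units; within the scatter). The value estimated for compound 4 is 6000 nM, between 2500 nM and 15000 nM.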

Compound 4, half-maximal inhibitory concentration: 163 nM
Estimate against measurement, compound 4: 37-fold (1.57 log units) above, and the stated range ends above it.
By their numbers in this assay, from the lowest: compound 4; then compounds 3 and 2 (each within the scatter of the next). At a limit, above all of these: compound 1.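

In this assay, going by these compounds alone, the earlier compounds offered no pair that isolated this position, and now one does: on the carbon with a double bond to nitrogen, naphthalen-2-yl in place of 4-chlorophenyl gives a 56-fold lower number from compound 2 to compound 4 (1.75 log units; beyond the scatter). A change at this single place can therefore shift the result far beyond the scatter. Nothing measured here explains the size of this step.

From the compounds shown here alone, this is a single pair, so whether the step would recur on a different core remains open. Also open, going by these compounds, is how an amine, a carboxylic acid or a longer chain at this position would compare.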